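Swapping trifluoromethyl for hydroxy on a weak growth inhibitor

The compounds below may be only part of what the source reports. "The series", "measured", "known", "first", "only" and "open" are said of these compounds alone.

- compound 1 `O=C(Nc1ccc(C(F)(F)F)cc1)c1ccc2ccccc2n1`: > 90000 nM (a limit)
- compound 2 `O=C(Nc1ccccc1O)C1CCc2ccccc2N1C(=O)c1ccc(Cl)cc1`: 19200 nM

In a functional assay on NCI-H23 cells (Homo sapiens) for cytotoxicity, read by sulforhodamine B assay, with a stated time of 72 h (a lower number here means a stronger inhibitor of growth, a higher number a weaker inhibitor of growth), compound 1 gives > 90000 nM, which is a limit of the assay and not a number. Compound 2, a compound of different structure, gives 19200 nM in this assay. Compound 3 `O=C(Nc1ccc(O)cc1)c1ccc2ccccc2n1` keeps the core of compound 1 and carries hydroxy in place of trifluoromethyl on an aromatic carbon, para to a large group: hydroxy in place of trifluoromethyl on an aromatic carbon. Among the measured compounds shown here, no measured pair shows this change, so the expectation rests on compound 1 alone, with its limit of > 90000 nM. The expected at least 1.8-fold lower number from compound 1 to compound 3 (0.25 log units; that floor lies within the scatter) is modest and points toward stronger growth inhibition, and the result may again be only a limit. Compound 3 is estimated at 50000 nM, with an expected range from 15000 nM to 90000 nM.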

Compound 3, concentration for 50% growth inhibition: 102000 nM
Compound 3: middle estimate off by 2.0-fold (0.31 log units), on the low side, outside the stated range (above it).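

No step can be read from compound 1 to compound 3, because the result for compound 1 is a limit and not a number: the limit of > 90000 nM in this assay, at which 1 of the 3 values shown sits.

The compounds shown leave open whether hydroxy in place of trifluoromethyl on an aromatic carbon changes growth inhibition in this assay at all.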